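A few compounds are considered here, and "the series" means these few. Any claim that something is new, unique, unknown or untested is made for them only; others in the source may bear on it.

Of the compounds shown here, three built on a shared design have been tested in a functional assay on MIA PaCa-2 cells (Homo sapiens) for antiproliferative activity, read by sulforhodamine B assay, with a stated time of 48 h; on this read-out higher numbers stand for weaker inhibition and lower numbers for stronger inhibition. Compound 1 `COc1ccc(C(=O)/C=C\Nc2ccc(-c3nc4cc(OC)c(OC)c(OC)c4s3)cc2C)cc1F` gives 1800 nM. Compound 2 `COc1ccc2nc(-c3ccc(N/C=C\C(=O)c4ccc(OC)c([N+](=O)[O-])c4)cc3)sc2c1` gives 23600 nM. Compound 3 `COc1cc(OC)c2sc(-c3ccc(N/C=C\C(=O)c4ccc(OC)c(F)c4)c(C)c3)nc2c1` gives 16300 nM. One pair differs in a single place: methoxy in place of hydrogen on an aromatic carbon. That change gave a 9.1-fold lower number from compound 3 to compound 1 (0.96 log units; beyond the scatter). The difference between the cores of compound 2 and compound 3 is not broken down here; their values lie close together, within the usual scatter.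

Compound 4 `COc1ccc2nc(-c3ccc(N/C=C\C(=O)c4cc(OC)c(OC)c([N+](=O)[O-])c4)cc3)sc2c1` has not yet been measured; it is derived from compound 2 by methoxy in place of hydrogen on an aromatic carbon. This is the same kind of change as the earlier one, but the surroundings differ: earlier the methoxy entered a ring that is part of a fused or bridged system of two rings, ortho to two methoxy groups, meta and para to a fused ring; now it enters a ring of carbon only, ortho to one methoxy group, meta to a large group and meta to a nitro group. Because the earlier step was a 9.1-fold lower number from compound 3 to compound 1 (0.96 log units; beyond the scatter), the step expected in this assay is a 3.0-fold lower number from compound 2 to compound 4 (0.47 log units; beyond the scatter), and the different surroundings argue for a smaller step. Compound 4 is thus expected to give about 8000 nM in this assay, with a likely range from 2500 nM to 25000 nM.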

Compound 4, half-maximal inhibitory concentration: 25600 nM
Estimate against measurement, compound 4: 3.2-fold (0.51 log units) below; the measured number lies above the stated range.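

In this assay, methoxy in place of hydrogen on an aromatic carbon gave a 1.1-fold higher number from compound 2 to compound 4 (0.04 log units; within the scatter), so on this core the change left the number where it was. The same kind of change behaved differently on the two cores, so its size did not carry from one to the other: the same change on two cores in this assay, a 9.1-fold lower number (0.96 log units; beyond the scatter) from compound 3 to compound 1 and a 1.1-fold higher number (0.04 log units; within the scatter) from compound 2 to compound 4, 9.8-fold (0.99 log units) apart, beyond the scatter of two such steps This shows that the step cannot be treated as a fixed amount in this series, but it does not show what sets the size of the step: the two pairs differ in their cores and in the ring that takes the methoxy, and also in the groups around it, and two pairs cannot separate these differences.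

The compounds shown leave open whether the nitro group, which sits meta to the new methoxy in compound 4, has any part in this result. They also leave open how a hydroxyl or an amine in place of that methoxy would behave on either core.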